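The source may report more compounds than this note shows. Statements on the series, on what has been measured and on what is new or still open speak of the compounds shown alone.

In a physicochemical assay for lipophilicity (a lower number here means a more polar compound, a higher number a more lipophilic compound), compound 1 `Cc1cc2nc(O)c(O)nc2c([N+](=O)[O-])c1C` gives 0.58 and compound 2 `CCc1cc2nc(O)c(O)nc2c([N+](=O)[O-])c1Cl` gives 0.92 as the higher of the two numbers, with the gap between them beyond the scatter. Compound 3 `Cc1cc2nc(O)c(O)nc2c([N+](=O)[O-])c1Cl` remains unmeasured and differs from compound 2 by hydrogen in place of methyl on a saturated chain carbon bound to an aromatic carbon in the form of hydrogen in place of methyl on a saturated chain carbon bound to an aromatic carbon, which reads as ethyl to methyl. Within the data shown here, no measured pair shows this change on its own. In this assay a downward step just beyond the scatter is expected, estimated as a number 0.37 log units lower from compound 2 to compound 3 (beyond the scatter) for this change. Compound 3 is expected at 0.55 with an estimated range from 0.25 to 0.85 when measured.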

Compound 3, partition coefficient: 0.44
Compound 3: middle estimate off by 0.11 log units, on the high side, within the range that was stated.
By their numbers in this assay, from the lowest: compounds 3 and 1 (each within the scatter of the next); then compound 2.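

Two single changes can now be read apart in this assay. Hydrogen in place of methyl on a saturated chain carbon bound to an aromatic carbon gives a number 0.48 log units lower from compound 2 to compound 3 (beyond the scatter) as its step, while chloro in place of methyl on an aromatic carbon gives a number 0.14 log units lower from compound 1 to compound 3 (within the scatter) as its step, so only the first of these steps registers beyond the scatter. Each change rests on a single pair. From the compounds shown here alone, whether a longer chain such as propyl, or an amine, on this carbon would extend the step stays open. Nothing available explains either step.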